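Swapping a benzyl substituent in two related indazole series

A few compounds are considered here, and "the series" means these few. Any claim that something is new, unique, unknown or untested is made for them only; others in the source may bear on it.

Four compounds share a common core and differ in two benzyl groups. Compound 1 `Cc1ccccc1CN(C)C(=O)c1cc2c(Cc3ccccc3)n[nH]c2cc1O` and compound 2 `CN(Cc1cccc(F)c1)C(=O)c1cc2c(Cc3ccccc3)n[nH]c2cc1O` have both been tested in a functional assay on A2780 cells (Homo sapiens) for antiproliferative activity, read by resazurin assay, with a stated time of 72 h; a higher number here means a weaker inhibitor, a lower number a stronger inhibitor. In this assay compound 1 gives 4400 nM, and compound 2 gives 5000 nM. The change between them is 3-fluorophenyl in place of 2-methylphenyl on a saturated chain carbon bound to an amide-type nitrogen, and it produced a 1.1-fold higher number from compound 1 to compound 2 (0.06 log units; within the scatter).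

Compound 3 `Cc1ccccc1Cc1n[nH]c2cc(O)c(C(=O)N(C)Cc3ccccc3)cc12` has the same atoms as compound 1, joined differently; the difference between the two cores is not broken down here. In this assay compound 3 gives "not determined" (no result reported), so no number is available for it. Compound 4 `CN(Cc1ccccc1)C(=O)c1cc2c(Cc3cccc(F)c3)n[nH]c2cc1O` is obtained from compound 3 by 3-fluorophenyl in place of 2-methylphenyl on a saturated chain carbon bound to an aromatic carbon. For the measured compounds named here, this is the same kind of change as the one from compound 1 to compound 2, but not the same: there it sits on a saturated chain carbon bound to an amide-type nitrogen, here on a saturated chain carbon bound to an aromatic carbon.

Compound 4 is expected to lie near compounds 1 and 2 in this assay because a 1.1-fold higher number from compound 1 to compound 2 (0.06 log units; within the scatter) was small. The estimate for compound 4 is 5000 nM, expected between 1500 nM and 16000 nM.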

Compound 4, half-maximal inhibitory concentration: 1700 nM
Estimate against measurement, compound 4: 2.9-fold (0.47 log units) above; low and high end bracket the measured number.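

No step can be read from compound 3 to compound 4 in this assay: compound 3 has no number there to set against compound 4. The compounds shown leave open what 3-fluorophenyl in place of 2-methylphenyl does on a saturated chain carbon bound to an aromatic carbon. Nothing available bears on the result for compound 4.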